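Fluorine in place of chlorine: compound 3 to compound 4

The source may report more compounds than this note shows. Statements on the series, on what has been measured and on what is new or still open speak of the compounds shown alone.

Measured so far in an assay on isolated protein for inhibition of Amine oxidase [flavin-containing] B (Homo sapiens), read by fluorescence, with a stated time of 15 min; on this read-out higher numbers stand for weaker inhibition and lower numbers for stronger inhibition:
- compound 1, `COc1ccc(/C=C/c2cc(OC)cc(OC)c2/C=C/C(=O)c2cc3ccccc3oc2=O)cc1`: 9170 nM
- compound 2, `COc1ccc(/C=C/c2cc(OC)cc(OC)c2/C=C/C(=O)c2cc3cc(OC)ccc3oc2=O)cc1`: > 60000 nM, a limit of the assay, not a number
- compound 3, `COc1ccc(/C=C/c2cc(OC)cc(OC)c2/C=C/C(=O)c2cc3ccc(Cl)cc3oc2=O)cc1`: 7360 nM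

Two numbers and one limit are at hand. Compound 3 and compound 1 cannot be told apart on them: the step of a 1.2-fold lower number from compound 1 to compound 3 (0.10 log units; within the scatter) sits within the scatter, so neither is called the stronger. The reading for compound 2 is only a limit, (the limit of > 60000 nM in this assay, at which 1 of the 3 values shown sits), and shows that methoxy in place of hydrogen on an aromatic carbon moved the number the wrong way, an at least 6.5-fold higher number from compound 1 to compound 2 (0.81 log units; beyond the scatter).

Compound 4, `COc1ccc(/C=C/c2cc(OC)cc(OC)c2/C=C/C(=O)c2cc3cc(F)ccc3oc2=O)cc1`, is not yet measured. The change from compound 3 is a group of 12 heavy atoms (9 carbon, 2 oxygen, 1 fluorine; one six-membered aromatic ring of carbon only, one six-membered aromatic ring with 1 hetero atom) in place of a group of 12 heavy atoms (9 carbon, 2 oxygen, 1 chlorine; one six-membered aromatic ring of carbon only, one six-membered aromatic ring with 1 hetero atom), on a carbonyl carbon. Among the measured compounds shown here, no measured pair carries fluorine, so the step has to be read by analogy. For the measured compounds named here, the closest guide is the chloro for hydrogen step, which changed nothing beyond the scatter; the methoxy step is the only one that moved the number clearly. A halogen swap at the same place is therefore expected to stay within the scatter in this assay, with no direction called.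

The estimate for compound 4 is 8000 nM, expected between 3500 nM and 18000 nM, a step of a 1.1-fold higher number from compound 3 to compound 4 (0.04 log units; within the scatter).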

Compound 4, half-maximal inhibitory concentration: 10200 nM
Compound 4: the middle estimate sits 1.3-fold (0.11 log units) below what was measured; the measured number falls inside the stated range.
By their numbers in this assay, from the lowest: compounds 3, 1 and 4 (each within the scatter of the next). At a limit, above all of these: compound 2.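

In this assay, the methoxy result does not extend to every group on that aromatic carbon: fluoro in place of hydrogen gives a 1.1-fold higher number from compound 1 to compound 4 (0.05 log units; within the scatter), and the exchange of the chlorine-bearing group for the fluorine-bearing group on a carbonyl carbon gives a 1.4-fold higher number from compound 3 to compound 4 (0.14 log units; within the scatter), so compounds 1, 3 and 4 cannot be told apart. Fluoro in place of methoxy on an aromatic carbon gives an at least 5.8-fold lower number from compound 2 to compound 4 (0.76 log units; beyond the scatter), which sets compound 2 apart as the one exception among the compounds shown and ties the clear shift to methoxy rather than to substitution at that carbon as such. Compound 2 is held at a limit of the assay, not a number, so this step gives only a bound: the limit of > 60000 nM in this assay, at which 1 of the 4 values shown sits.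

No group shown on the shared core gives a number lower than that of compound 1 by more than the scatter, so no change that strengthens inhibition has yet been identified. On these data alone, whether the methoxy result carries over to hydroxy, methyl, ethoxy or an amine on that same aromatic carbon remains open.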